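Compound 3 to compound 4: a change of aryl group

This account rests on a few compounds, and the source may have more. Where it says the series, first, only, none or still open, it means among the compounds named here.

Measured in a functional assay on MDA-MB-435 cells (Homo sapiens) for cytotoxicity, read by MTT assay, with a stated time of 72 h; a higher number here means a weaker inhibitor, a lower number a stronger inhibitor:
- compound 1 `O=C(NCc1ccc(F)cc1)c1nc(NCCO)c2cccnc2c1O`: > 20000 nM (a limit)
- compound 2 `O=C(NCc1ccc(F)cc1)c1nc(Br)c2cccnc2c1NCc1ccc(F)cc1`: > 20000 nM (a limit)
- compound 3 `COc1cccc(CNC(=O)c2nc(Br)c3cccnc3c2N[C@H]2CC[C@H](N)CC2)c1`: 7000 nM

Among the compounds with values here, compound 3 holds the only number in this set, since the values of compound 1 and compound 2 are both limits. Compound 4 `N[C@H]1CC[C@H](Nc2c(C(=O)NCc3ccc(Cl)cc3)nc(Br)c3cccnc23)CC1` has not yet been measured. Its difference from compound 3 is 4-chlorophenyl in place of 3-methoxyphenyl on a saturated chain carbon bound to an amide-type nitrogen. In words, 4-chlorophenyl stands in place of 3-methoxyphenyl on a saturated chain carbon bound to an amide-type nitrogen.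

Within the data shown here, no pair of measured compounds differs in one place only, so the series gives no direct guide to this change. The expectation therefore rests on compound 3 at 7000 nM, with no step beyond the usual scatter expected in either direction. The expected change is a 1.2-fold lower number from compound 3 to compound 4 (0.07 log units; within the scatter). A result reported only as a limit is still expected to be possible, with the limit of > 20000 nM in this assay, at which 2 of the 3 values shown sit, in view. For compound 4 the estimated value is 6000 nM, with an expected range from 2000 nM to 20000 nM.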

Compound 4, half-maximal inhibitory concentration: 1000 nM
The estimate for compound 4 lay 6.0-fold (0.78 log units) above the measured number; the whole stated range lies above it.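

In this assay, 4-chlorophenyl in place of 3-methoxyphenyl on a saturated chain carbon bound to an amide-type nitrogen gives a 7.0-fold lower number from compound 3 to compound 4 (0.85 log units; beyond the scatter). Within the data shown here, this is the first comparison that changes one place only, and it shows that the aryl group at this position can move the number beyond the scatter, which the earlier compounds could not show. It is a single step, however, and it exchanges both the substituent and its printed ring position, 3-methoxy for 4-chloro, so it cannot assign the shift to either one, and nothing shown gives a cause for it.

Still open, on these data alone, is whether the chlorine, the loss of the methoxy group or the ring position carries the step; 3-chlorophenyl, 4-methoxyphenyl and unsubstituted phenyl at this position would separate these readings. Also open, as far as these compounds go, is whether the shift holds on other members, as a 4-fluorophenyl or 4-bromophenyl group here would only extend this one comparison on the same core.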